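This account rests on a few compounds, and the source may have more. Where it says the series, first, only, none or still open, it means among the compounds named here.

Measured compounds:
compound 1 `Cc1ccc(C(=O)N/N=C/C2=C(Cl)c3cc(C)c(C)cc3CCC2)cc1`: > 100000 nM
compound 2 `Cc1cc2c(cc1C)C(Cl)=C(/C=N/NC(=O)c1cccc(Cl)c1)CCC2`: 770 nM

In a functional assay on HeLa cells (Homo sapiens) for inhibition, read by sulforhodamine B assay, with a stated time of 48 h (a lower number here means a stronger inhibitor of growth, a higher number a weaker inhibitor of growth), compound 1 reaches only (the limit of > 100000 nM in this assay, at which 1 of the 2 values shown sits), which is a limit of the assay and not a number. Compound 2 gives 770 nM in this assay, the one real number shown, and it stands as the stronger of the two. The step of an at least 120-fold lower number from compound 1 to compound 2 (2.11 log units; beyond the scatter) shows that the aromatic group on the carbonyl carbon matters greatly for these two compounds. Compound 3 `Cc1cc2c(cc1C)C(Cl)=C(/C=N/NC(=O)c1ccccc1N)CCC2` is not yet measured; it differs from compound 2 by 2-aminophenyl in place of 3-chlorophenyl on a carbonyl carbon. Among the measured compounds shown here, the single measured step bears on this change only by showing how far a swap at that place can move the result; it does not say which way the 2-aminophenyl group will move it. Therefore the estimated change, a 6.5-fold higher number from compound 2 to compound 3 (0.81 log units; beyond the scatter), is a weakening with wide uncertainty. For compound 3 the expected value in this assay is 5000 nM, between 800 nM and 60000 nM.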

Compound 3, concentration for 50% growth inhibition: > 100000 nM
Compound 3 gave a limit, no number; the forecaster's own chance of this, stated with the estimate: 30%; middle value at least 20-fold (1.30 log units) from the limit.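

In this assay compound 3 gives > 100000 nM, which is a limit of the assay and not a number. Even so, 2-aminophenyl in place of 3-chlorophenyl gives an at least 120-fold higher number from compound 2 to compound 3 (2.11 log units; beyond the scatter), so this place on the carbonyl carbon has now shown a large change in two separate swaps, not one. Of the three aromatic groups shown at this place, only 3-chlorophenyl gives a real number: the limit of > 100000 nM in this assay, at which 2 of the 3 values shown sit.

The step between the two limits, from compound 1 to compound 3, cannot be read, so 4-methylphenyl and 2-aminophenyl cannot be ranked against each other. From the compounds shown here alone, it also remains open whether the chlorine itself is what counts, a question that 3-methylphenyl, 4-chlorophenyl or 3-bromophenyl at this place could help to answer.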